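The source may hold more compounds than are shown below. What is called first, only, known or untested is meant among the compounds shown, and "the series" means these compounds.

Measured in a functional assay on PC-3 cells (Homo sapiens) for cytotoxicity, read by MTT assay, with a stated time of 72 h; on this read-out lower numbers stand for stronger inhibition and higher numbers for weaker inhibition:
Compound 1 `COc1ccc2[nH]c(-c3ccc[nH]3)c(C3CC(=O)NC3=O)c2c1`: 6000 nM
Compound 2 `c1ccc2[nH]c(-n3cccn3)cc2c1`: > 100000 nM (a limit of the assay, not a number)
Compound 3 `COc1ccc2[nH]c(-c3ccc[nH]3)cc2c1`: 26000 nM

Compound 1 has the lower of the two actual numbers in this assay, and compound 3 is its nearest neighbour. Compound 2 gives only a limit, (the limit of > 100000 nM in this assay, at which 1 of the 3 values shown sits).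

The next compound, compound 4 `Cc1ccc2[nH]c(-c3ccc[nH]3)c(C3CC(=O)NC3=O)c2c1`, differs from compound 1 in one place, with methyl in place of methoxy on an aromatic carbon. Within the data shown here, no measured step tests this swap directly. Among the measured compounds shown here, the only measured step, a 4.3-fold higher number from compound 1 to compound 3 (0.64 log units; beyond the scatter), is modest and removes a different group, one that compound 4 keeps. It therefore offers only a loose guide to size and none to direction. No step beyond the scatter is expected in this assay, and the estimated step is a 1.2-fold higher number from compound 1 to compound 4 (0.07 log units; within the scatter). Compound 4 is expected to give about 7000 nM, with an estimated range of 2500 nM to 20000 nM.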

Compound 4, half-maximal inhibitory concentration: 11000 nM
Estimate against measurement, compound 4: 1.6-fold (0.20 log units) below, and the stated range covers the measured number.
By their numbers in this assay, from the lowest: compounds 1 and 4 (each within the scatter of the next); then compound 3. At a limit, above all of these: compound 2.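

In this assay, the change from methoxy to methyl on this aromatic carbon gives a 1.8-fold higher number from compound 1 to compound 4 (0.26 log units; within the scatter) and so stays within the usual scatter. Among these compounds, this is the first direct reading at this position, since the only earlier step concerned the loss of the 2,5-dioxopyrrolidin-3-yl group at a different place on the shared core. Here, the oxygen and the hydrogen-bond acceptor of methoxy can go without a measurable loss in this cell assay, and nothing measured here explains that result.

Still open, going by these compounds, is how a group of a different kind at this position, such as an amine, a chlorine atom or a longer chain like ethoxy, would compare. On these data alone, it is also open whether the same swap would read alike on a core without the 2,5-dioxopyrrolidin-3-yl group.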